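A few compounds are considered here, and "the series" means these few. Any claim that something is new, unique, unknown or untested is made for them only; others in the source may bear on it.

Measured so far in an ADME assay on HEK-293T cells (Homo sapiens) for cytotoxicity, with a stated time of 72 h; a higher number here means that more compound is tolerated, a lower number that less compound is tolerated:
Compound 1 `CC(C)C[C@H](NC(=O)OC1CCC(C)(C)CC1)C(=O)N[C@H](C=O)C[C@@H]1CCNC1=O`: > 100000 nM, a limit of the assay.
Compound 2 `CC(C)C[C@H](NC(=O)OC1CCC(C)(C)CC1)C(=O)N[C@@H](C[C@@H]1CCNC1=O)C(O)S(=O)(=O)O`: > 100000 nM, a limit of the assay.
Compound 3 `CCCC[C@H]1CC[C@H](OC(=O)N[C@@H](CC(C)C)C(=O)N[C@H](C=O)C[C@@H]2CCNC2=O)CC1`: 55000 nM.

Among the compounds with values here, compound 3 gives the only numerical value of the three; the other two sit at the limit of > 100000 nM in this assay, at which 2 of the 3 values shown sit. The step of an at least 1.8-fold lower number from compound 1 to compound 3 (0.25 log units; that floor lies within the scatter) thus rests on one limit and one number. Compound 4 `CCCC[C@H]1CC[C@H](OC(=O)N[C@@H](CC(C)C)C(=O)N[C@@H](C[C@@H]2CCNC2=O)C(O)S(=O)(=O)O)CC1` carries the change (hydroxy(sulfo)methyl in place of formyl on a saturated chain carbon bound to an amide-type nitrogen and a saturated chain carbon). The same change is present in the measured step that the two limits leave unreadable from compound 1 to compound 2, which begins and ends in a limit and so gives no size. Within the data shown here, no measured step tells how this change moves this assay. Among the measured compounds shown here, the expectation for compound 4 leans on the one number, compound 3 at 55000 nM, and on compound 2 reaching (the limit of > 100000 nM in this assay, at which 2 of the 3 values shown sit). With no readable precedent, the estimate is a step of a 1.5-fold higher number from compound 3 to compound 4 (0.16 log units; within the scatter), small and within the scatter. Compound 4 is therefore expected at 80000 nM, range 35000 nM to 200000 nM, with a fair chance that only a limit is reported.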

Compound 4, half-maximal cytotoxic concentration: 58000 nM
Compound 4: the middle estimate sits 1.4-fold (0.14 log units) above what was measured; low and high end bracket the measured number.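

In this assay, hydroxy(sulfo)methyl in place of formyl on a saturated chain carbon bound to an amide-type nitrogen and a saturated chain carbon now has a readable size, a 1.1-fold higher number from compound 3 to compound 4 (0.02 log units; within the scatter), with the 4-butylcyclohexyl group present. The matching step with the 4,4-dimethylcyclohexyl group begins and ends in a limit and cannot be read. The exchange of the two cyclohexyl groups can now be followed with hydroxy(sulfo)methyl as well, an at least 1.7-fold lower number from compound 2 to compound 4 (0.23 log units; that floor lies within the scatter), which gives it a second core: the same change on two cores in this assay, an at least 1.8-fold lower number (0.25 log units; that floor lies within the scatter) from compound 1 to compound 3 and an at least 1.7-fold lower number (0.23 log units; that floor lies within the scatter) from compound 2 to compound 4; the limit leaves it open whether they differ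

As far as these compounds go, compound 1 and compound 2 both stand at a limit, and how far apart they lie stays open: the limit of > 100000 nM in this assay, at which 2 of the 4 values shown sit. Also open is how a carboxylic acid in place of hydroxy(sulfo)methyl, or a longer chain in place of butyl, would read here.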